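The source may hold more compounds than are shown below. What is called first, only, known or untested is meant among the compounds shown, and "the series" means these compounds.

Compound 3, with the structure `O=C(COc1ccc(/C=C2\SC(=O)NC2=O)cc1)Nc1ccccn1`, stands in a functional assay on HepG2 cells (Homo sapiens) for cytotoxicity, read by sulforhodamine B assay, with a stated time of 48 h (on this read-out lower numbers stand for stronger inhibition of growth and higher numbers for weaker inhibition of growth), at < 100000 nM, which is a limit of the assay and not a number. Compound 1, with the structure `Cc1cnc(NC(=O)COc2ccc(/C=C3\SC(=O)NC3=O)cc2)s1`, gives in this assay < 100000 nM, again a limit. Compound 2, with the structure `O=C(COc1ccc(/C=C2\SC(=O)NC2=O)cc1)Nc1ncc([N+](=O)[O-])s1`, gives < 100000 nM, likewise a limit. The steps a step that the two limits leave unreadable from compound 1 to compound 2, a step that the two limits leave unreadable from compound 1 to compound 3 and a step that the two limits leave unreadable from compound 2 to compound 3 cannot be sized because of the limit of < 100000 nM in this assay, at which 3 of the 3 values shown sit. Compound 4, with the structure `Cc1cc(NC(=O)COc2ccc(/C=C3\SC(=O)NC3=O)cc2)no1`, differs from compound 3 in one place: 5-methyl-1,2-oxazol-3-yl in place of pyridin-2-yl on an amide-type nitrogen. Among the compounds with values here, none of the measured steps gives a readable size, so no step beyond the scatter can be expected. Compound 4 is therefore expected to sit at about 50000 nM, between 10000 nM and 100000 nM, most likely again as a limit. The expected step that the limit leaves unreadable from compound 3 to compound 4 is thus essentially flat.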

Compound 4, concentration for total growth inhibition: < 100000 nM
Compound 4 ended at the assay's limit; the forecaster's own chance of this, stated with the estimate: 70%; the middle value lies beyond the limit too.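

The steps linking compound 4 with compound 1, compound 2 and compound 3 cannot be read, because each compound sits at a limit: the limit of < 100000 nM in this assay, at which 4 of the 4 values shown sit.

The compounds shown leave open how the groups on the amide-type nitrogen rank in this assay.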